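Replacing the methoxy arm with a methyl on the acid-bearing carbon

This account rests on a few compounds, and the source may have more. Where it says the series, first, only, none or still open, it means among the compounds named here.

Of the compounds shown here, two have been measured in a functional assay on HFL1 cells for antagonist activity at sphingosine 1-phosphate receptor 2 (Homo sapiens), read by ELISA, with a stated time of 24 h, in the presence of a further agent that is not named here (on this read-out higher numbers stand for weaker inhibition and lower numbers for stronger inhibition), so far. Compound 1, `O=C(O)Cn1nc(Cn2cc3cc(OCC4CC4)c(Cl)cc3n2)c2ccccc2c1=O`, gives 647 nM in this assay. Compound 2, `COC(C(=O)O)c1nn(Cc2cn3cc(OCC4CC4)c(Cl)cc3n2)c2ccccc2c1=O`, gives 217 nM in this assay, the lowest of the two numbers; the number for compound 1 is higher, a gap beyond the usual scatter.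

Compound 3, `C[C@H](C(=O)O)c1nn(Cc2cn3cc(OCC4CC4)c(Cl)cc3n2)c2ccccc2c1=O`, differs from compound 2 in one place: 1-carboxyethyl in place of carboxy(methoxy)methyl on an aromatic carbon. The carboxylic acid stays, and the methoxy group beside it is exchanged for a methyl with a defined stereocentre. Among the compounds with values here, no measured pair shows the effect of this change, so the size of the step in this assay is unknown; a modest shift in either direction, quite possibly within the scatter, seems the most reasonable expectation.

On that basis compound 3 is expected to give about 250 nM in this assay, within a range from 100 nM to 650 nM. The estimated step of a 1.2-fold higher number from compound 2 to compound 3 (0.06 log units; within the scatter) is expected to stay close to the scatter.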

Compound 3, half-maximal inhibitory concentration: 19 nM
The estimate for compound 3 lay 13-fold (1.12 log units) above the measured number, and the stated range ends above it.
By their numbers in this assay, from the lowest: compound 3; then compound 2; then compound 1.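

In this assay, putting 1-carboxyethyl in place of carboxy(methoxy)methyl on this aromatic carbon gives an 11-fold lower number from compound 2 to compound 3 (1.06 log units; beyond the scatter) and so shows that the read-out responds strongly to a small change in the group carrying the acid. This is not a single change, since the entering group has fewer oxygen atoms and hydrogen-bond acceptors and also has a defined stereocentre that the leaving group lacks, and the step cannot be divided among these differences. Nothing available accounts for the size of this step.

The compounds shown leave open how the opposite configuration at this stereocentre would compare with compound 3. They also leave open whether an ethyl or a hydroxy group on the acid-bearing carbon would keep the lower number, and whether an amide could stand in for the carboxylic acid.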